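The source may hold more compounds than are shown below. What is called first, only, known or untested is meant among the compounds shown, and "the series" means these compounds.

In a functional assay on cells (Cancer cell lines, Homo sapiens) for cytotoxicity, read by sulforhodamine B assay, with a stated time of 48 h (on this read-out lower numbers stand for stronger inhibition of growth and higher numbers for weaker inhibition of growth), three compounds have been measured:

Compound 1, `COc1ccc(C2=NN(C3=NC(=O)/C(=C4\C(=O)Nc5ccc(Br)cc54)S3)C(c3ccc(Cl)cc3)C2)cc1`, gives 140 nM.
Compound 2, `COc1ccc(C2=NN(C3=NC(=O)/C(=C4\C(=O)Nc5ccc(Cl)cc54)S3)C(c3ccc(Cl)cc3)C2)cc1`, gives 200 nM.
Compound 3, `CN(C)c1ccc(C2CC(c3ccccc3)=NN2C2=NC(=O)/C(=C3\C(=O)Nc4ccc(Br)cc43)S2)cc1`, gives 220 nM.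

Compound 1 and compound 2 differ by one change, (chloro in place of bromo on an aromatic carbon), and that change gave a 1.4-fold higher number from compound 1 to compound 2 (0.15 log units; within the scatter). Compound 3 differs from compound 1 in more than one place; the difference between the two cores is not broken down here. Compound 4, `CN(C)c1ccc(C2CC(c3ccccc3)=NN2C2=NC(=O)/C(=C3\C(=O)Nc4ccc(Cl)cc43)S2)cc1`, has not been measured. It differs from compound 3 by chloro in place of bromo on an aromatic carbon, the same change as from compound 1 to compound 2, at a place described in the same words. Because a 1.4-fold higher number from compound 1 to compound 2 (0.15 log units; within the scatter) was within the scatter, compound 4 is expected to differ from compound 3 by a 1.4-fold higher number from compound 3 to compound 4 (0.13 log units; within the scatter). Compound 4 is therefore estimated at 300 nM, with the likely range from 150 nM to 600 nM.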

Compound 4, concentration for 50% growth inhibition: 220 nM
For compound 4 the middle estimate is 1.4-fold (0.13 log units) above the measured one; the measured number falls inside the stated range.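

In this assay, chloro in place of bromo on an aromatic carbon gave no change at the digits printed from compound 3 to compound 4 (within the scatter). Set beside the same change on the core of compound 1, the new step agrees with the earlier one: the same change on two cores in this assay, a 1.4-fold higher number (0.15 log units; within the scatter) from compound 1 to compound 2 and no change at the digits printed (within the scatter) from compound 3 to compound 4, 1.4-fold (0.15 log units) apart, within the scatter of two such steps. On these two cores, then, the change stays within the scatter and carries over from one core to the other, but this does not show that it has any real effect on growth inhibition, nor does it extend to other cores.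

The compounds shown leave open whether a different group at this place, such as fluoro, methoxy or an amine, would move the number beyond the scatter.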